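Replacing furan-3-yl with pyridin-2-yl on the shared core

The source may report more compounds than this note shows. Statements on the series, on what has been measured and on what is new or still open speak of the compounds shown alone.

Measured in an ADME assay on BHK-21 cells (Mesocricetus auratus) for cytotoxicity, read by MTT assay; a higher number here means that more compound is tolerated, a lower number that less compound is tolerated:
Compound 1 `C/C(=N\NC(N)=S)c1ccc2c(c1)nc(-c1ccccc1)n2C1CCCCC1`: 38000 nM
Compound 2 `COc1ccc(-c2nc3cc(/C(C)=N/NC(N)=S)ccc3n2C2CCCCC2)cc1`: "not determined" (no result reported)
Compound 3 `C/C(=N\NC(N)=S)c1ccc2c(c1)nc(-c1ccoc1)n2C1CCCCC1`: > 100000 nM, a limit and not a number

Compound 3 has no single number, since it sits at the limit of > 100000 nM in this assay, at which 1 of the 3 values shown sits. Compound 4 `C/C(=N\NC(N)=S)c1ccc2c(c1)nc(-c1ccccn1)n2C1CCCCC1` differs from compound 3 in one place, with pyridin-2-yl in place of furan-3-yl on an aromatic carbon.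

Among the compounds with values here, only one measured step bears on this change: an at least 2.6-fold higher number from compound 1 to compound 3 (0.42 log units; beyond the scatter), with furan-3-yl in place of phenyl. On these data alone, that step ends at a limit, so its true size stays open. Pyridin-2-yl has a six-membered aromatic ring, as phenyl does, and one hetero atom, as furan-3-yl does. Compound 1, with phenyl, gives 38000 nM, so the new group is expected to land somewhere between the two ends of that step. A modest move to a lower number in this assay is therefore expected, although another result at the limit would be no surprise. The step expected is an at least 1.5-fold lower number from compound 3 to compound 4 (0.18 log units; that floor lies within the scatter). Compound 4 is estimated at 65000 nM, with an expected range of 28000 nM to 140000 nM.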

Compound 4, half-maximal cytotoxic concentration: 24000 nM
Estimate against measurement, compound 4: 2.7-fold (0.43 log units) above, outside the stated range (below it).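

In this assay, pyridin-2-yl in place of furan-3-yl on this aromatic carbon gives an at least 4.1-fold lower number from compound 3 to compound 4 (0.61 log units; beyond the scatter), so the high tolerance seen with furan-3-yl does not extend to every ring with one hetero atom at this place. Set against phenyl, pyridin-2-yl gives a 1.6-fold lower number from compound 1 to compound 4 (0.20 log units; within the scatter), so the two six-membered aromatic rings cannot be told apart in this assay, and among the three compounds with a reported result, compound 3 alone stands clearly apart from the other two. Compound 3 holds only a limit and not a number, so the full size of its separation stays unknown because of where it sits: the limit of > 100000 nM in this assay, at which 1 of the 4 values shown sits.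

The compounds shown leave open whether the five-membered ring or its oxygen sets compound 3 apart, a question that a thiophene or a pyrrole ring at this place would help to settle. They also leave open whether the place of the nitrogen within the six-membered ring matters, as a pyridin-4-yl group would show.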